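Trading 4-Methoxyphenyl for 3,4-Dichlorophenyl on the Shared Core

The source may report more compounds than this note shows. Statements on the series, on what has been measured and on what is new or still open speak of the compounds shown alone.

Compound 3 `COc1ccc(-c2cc3ccc(OCCCCCn4cc(CNC(=O)CCCCC5CCSS5)nn4)cc3oc2=O)cc1` gives 49% in a functional assay on PC-12 cells (Rattus norvegicus) for cytotoxicity, read by MTT assay, with stated times of 3 h and 2 h, tested at 20 uM (a higher number here means a stronger effect of the compound at the concentration tested, a lower number a weaker effect), the second highest of three numbers. Compound 1 `O=C(CCCCC1CCSS1)NCc1cn(CCCCCOc2ccc3ccc(=O)oc3c2)nn1` gives 78.5%, and compound 2 `CC(=O)c1cc2ccc(OCCCCCn3cc(CNC(=O)CCCCC4CCSS4)nn3)cc2oc1=O` gives 20.7%. The measured steps show a number 29.5 percentage points lower from compound 1 to compound 3 (beyond the scatter) and a number 28.3 percentage points higher from compound 2 to compound 3 (beyond the scatter), so the group at this position moves the read-out by modest to large amounts. Compound 4 `O=C(CCCCC1CCSS1)NCc1cn(CCCCCOc2ccc3cc(-c4ccc(Cl)c(Cl)c4)c(=O)oc3c2)nn1` carries 3,4-dichlorophenyl in place of 4-methoxyphenyl on an aromatic carbon. Within the data shown here, no measured step exchanges one aryl group for another, so the direction is uncertain, and a change of modest size either way seems possible. Compound 4 is therefore estimated at 45%, within 20% to 75%, which means an expected step of a number 4 percentage points lower from compound 3 to compound 4 (within the scatter).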

Compound 4, a percentage reported as activity, at one concentration (the size of the read-out at that concentration, not a potency): 65.5%
Compound 4: middle estimate off by 20.5 percentage points, on the low side; the measured number falls inside the stated range.
By their numbers in this assay, from the lowest: compound 2; then compound 3; then compound 4; then compound 1.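

Replacing 4-methoxyphenyl with 3,4-dichlorophenyl gives a number 16.5 percentage points higher from compound 3 to compound 4 (beyond the scatter) in this assay, the first sign that the read-out depends on which aryl group sits here. Exchanging acetyl for this aryl group gives a number 44.8 percentage points higher from compound 2 to compound 4 (beyond the scatter) in the same test. Exchanging hydrogen for it gives a number 13 percentage points lower from compound 1 to compound 4 (beyond the scatter) here, so neither aryl group shown reaches the number of the compound with hydrogen. Nothing measured here explains the difference between the two aryl groups. On these data alone, how an unsubstituted phenyl or a carboxylic acid at this position would read remains open.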